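The compounds below may be only part of what the source reports. "The series", "measured", "known", "first", "only" and "open" are said of these compounds alone.

Working notes on the series. Compound 1 `COc1ccc(C(=O)/C=C/c2cc(-c3cc(OC)c(OC)c(OC)c3)n[nH]2)cc1OC` is the reference point: in a functional assay on Malme-3M cells (Homo sapiens) for cytotoxicity, read by sulforhodamine B assay, with a stated time of 48 h, tested at 10 uM (a lower number here means a stronger effect, a higher number a weaker effect of the compound at the concentration tested), compound 1 gives -82%. Compound 2 `COc1ccc(C(=O)/C=C/c2cc(-c3cc(OC)c(OC)c(OC)c3)n[nH]2)cc1` differs from it by hydrogen in place of methoxy on an aromatic carbon, and in this assay compound 2 gives -66%. Among the measured compounds shown here, the only measured step in the set, a number 16 percentage points higher from compound 1 to compound 2 (beyond the scatter), puts compound 2 as the higher of the two numbers, beyond the scatter from compound 1, so within what has been measured compound 2 shows the weaker effect.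

Compound 3 `COc1cc(-c2cc(/C=C/C(=O)c3ccc(F)c(F)c3)[nH]n2)cc(OC)c1OC` is not yet measured. Relative to compound 2 the change is 3,4-difluorophenyl in place of 4-methoxyphenyl on a carbonyl carbon. For the measured compounds named here, no measured step matches this exchange, so the step of a number 16 percentage points higher from compound 1 to compound 2 (beyond the scatter) is the only guide; it shows that taking away a methoxy raised the number modestly. Compound 3 gives up the remaining methoxy as part of a larger exchange, so a further rise is expected, and the step is expected to be a number 16 percentage points higher from compound 2 to compound 3 (beyond the scatter). Going by the values given here, for compound 3 the estimate in this assay is -50%, expected to lie between -75% and -20%, with wide uncertainty since the difluorophenyl has no measured precedent here.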

Compound 3, a percentage reported as activity, at one concentration (the size of the read-out at that concentration, not a potency): -3%
Estimate against measurement, compound 3: 47 percentage points below; the measured number lies above the stated range.
By their numbers in this assay, from the lowest: compound 1; then compound 2; then compound 3.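

In this assay the group on the carbonyl carbon matters far more than the modest earlier step suggested: removing one methoxy gave a number 16 percentage points higher from compound 1 to compound 2 (beyond the scatter) and the new exchange for 3,4-difluorophenyl gives a number 63 percentage points higher from compound 2 to compound 3 (beyond the scatter) while the same exchange measured against the dimethoxy compound gives a number 79 percentage points higher from compound 1 to compound 3 (beyond the scatter) as a second large step. Compound 3 (-3%) therefore shows the weakest effect of the three at the concentration tested, and the two fluorine atoms do not stand in for the methoxy groups at this position, although the aromatic ring and the heavy-atom count of the group are unchanged. Nothing shown here accounts for the size of this loss.

The compounds shown do not separate the loss of the methoxy groups from the arrival of the fluorine atoms, so it stays open whether a plain phenyl on the carbonyl carbon would sit nearer compound 2 or compound 3. Also open, from the compounds shown here alone, is how a hydroxyl, an amine or a carboxylic acid on that ring would read, and whether the same exchange behaves alike with other groups on the shared core.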